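The compounds below may be only part of what the source reports. "The series", "measured", "known", "first", "only" and "open" are said of these compounds alone.

Measured in an ADME assay on cells (Fibroblast, Homo sapiens) for antiproliferative activity, with a stated time of 48 h; a lower number here means a stronger inhibitor, a higher number a weaker inhibitor:
- Compound 1 `CCN(CC)c1ccc(-c2cccc(C#N)c2)nn1`: > 25000 nM, a limit
- Compound 2 `CCOC(=O)c1cccc(-c2ccc(N(CC)CC)nn2)c1`: > 25000 nM, a limit

Compound 1 therefore has no numerical value and stands only at a limit, as does the other compound measured: the limit of > 25000 nM in this assay, at which 2 of the 2 values shown sit. Compound 3 `CCCCOc1ccc(-c2cccc(C#N)c2)nn1` keeps the cyano group of compound 1 and differs from it in one place: butoxy in place of diethylamino on an aromatic carbon. Butoxy thus takes the place of diethylamino on an aromatic carbon.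

Among the compounds with values here, the one measured step is a step that the two limits leave unreadable from compound 1 to compound 2. It places ethoxycarbonyl where cyano stood, so it does not touch the group exchanged here, and it gives no size to carry over. Within the data shown here, no measured step bears directly on the exchange of diethylamino for butoxy.

The expectation rests on compound 1, whose > 25000 nM is a limit. No step beyond the scatter is expected in this assay, in either direction, although the data cannot exclude a stronger inhibitor. The estimated step is a number no higher from compound 1 to compound 3 (the limit leaves the size open). Compound 3 is expected at about 25000 nM, with an estimated range from 10000 nM to 50000 nM.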

Compound 3, half-maximal inhibitory concentration: > 25000 nM
Compound 3 gave a limit, no number; the forecaster's own chance of this, stated with the estimate: 75%; the middle value lies on the limit itself.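

In this assay, within the data shown here, compound 3 also stands only at a limit, so no step from compound 1 to compound 3 can be read, and the same holds for compound 2: the limit of > 25000 nM in this assay, at which 3 of the 3 values shown sit.

The compounds shown leave open how strongly any of them inhibits, and whether exchanging diethylamino for butoxy or cyano for ethoxycarbonyl makes any difference.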